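Removing the trifluoromethyl from the benzamide of compound 2

The compounds below may be only part of what the source reports. "The series", "measured", "known", "first", "only" and "open" are said of these compounds alone.

Three compounds have been measured in a functional assay on COLO 205 cells (Homo sapiens) for inhibition, read by sulforhodamine B assay, with a stated time of 48 h; on this read-out higher numbers stand for lower toxicity in this test and lower numbers for higher toxicity in this test:

compound 1 `O=C(Nc1cccc(-n2cc(-c3ccncc3)c(-c3ccc(Cl)c(O)c3)n2)c1)Nc1cccc(C(F)(F)F)c1`: > 32500 nM, a limit of the assay
compound 2 `COc1cc(-c2nn(-c3cccc(NC(=O)c4cccc(C(F)(F)F)c4)c3)cc2-c2ccncc2)ccc1Cl`: 24800 nM
compound 3 `O=C(Nc1cccc(-n2cc(-c3ccncc3)c(-c3ccc(Cl)c(O)c3)n2)c1)Nc1cc(C(F)(F)F)cc(C(F)(F)F)c1`: 2920 nM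

Of the two numbers, compound 2 stands highest, and compound 3 gives the lower one. Compound 1 sits at the limit of > 32500 nM in this assay, at which 1 of the 3 values shown sits. For the measured compounds named here, the only step between measured compounds that differ in one place is an at least 11-fold lower number from compound 1 to compound 3 (1.04 log units; beyond the scatter), a change that took the number far downward.

Compound 4 `COc1cc(-c2nn(-c3cccc(NC(=O)c4ccccc4)c3)cc2-c2ccncc2)ccc1Cl` has not yet been measured. It differs from compound 2 by hydrogen in place of trifluoromethyl on an aromatic carbon. This is the reverse of the change from compound 1 to compound 3, so the number for compound 4 is expected to move upward in this assay, with a real chance that only a limit is reported. Compound 4 is therefore expected to give 45000 nM, within 15000 nM to 120000 nM. The expected step is a 1.8-fold higher number from compound 2 to compound 4 (0.26 log units; within the scatter).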

Compound 4, concentration lethal to 50% of the cells: 68400 nM
Compound 4: the middle estimate sits 1.5-fold (0.18 log units) below what was measured, within the range that was stated.
By their numbers in this assay, from the lowest: compound 3; then compound 2; then compound 4.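

In this assay, taking the trifluoromethyl off the benzamide gave a 2.8-fold higher number from compound 2 to compound 4 (0.44 log units; beyond the scatter), so a change at this position now reads beyond the scatter on a second core, in the same direction as on the core of compound 1. The change does not carry over in equal size from one core to the other: the same change on two cores in this assay, an at least 11-fold lower number (1.04 log units; beyond the scatter) from compound 1 to compound 3 and a 2.8-fold lower number (0.44 log units; beyond the scatter) from compound 4 to compound 2, at least 4.0-fold (0.60 log units) apart, beyond the scatter of two such steps. From the compounds shown here alone, the larger of these two steps starts from a value that is only a limit, so its true size stays unknown: the limit of > 32500 nM in this assay, at which 1 of the 4 values shown sits.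

The compounds shown leave open whether another group at this place on the benzamide, such as an amine or a carboxylic acid, would move the number as trifluoromethyl does. They also leave open which of the several differences between the core of compound 1 and the core of compound 2 sets the size of the step.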